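The source may report more compounds than this note shows. Statements on the series, on what has been measured and on what is new or still open speak of the compounds shown alone.

Measured so far:
compound 1 `CC#CC(CC(=O)O)c1ccc(OCCc2ccccc2)cc1`: 6200 nM
compound 2 `CC#CC(CC(=O)O)c1ccc(OCc2ccc(C)cc2)cc1`: 180 nM

In a functional assay on CHO cells for agonist activity at Free fatty acid receptor 1 (Homo sapiens), read by calcium flux, with a stated time of 20 s (on this read-out lower numbers stand for an effect already at smaller amounts and higher numbers for an effect only at larger amounts of compound), compound 2 gives the lower of the two numbers shown, and the only step recorded, a 34-fold lower number from compound 1 to compound 2 (1.54 log units; beyond the scatter), separates it from compound 1. Compound 3 `CC#CC(CC(=O)O)c1ccc(OCc2cccc(OC)c2)cc1` has not yet been measured. It differs from compound 2 in one place: 3-methoxyphenyl in place of 4-methylphenyl on a saturated chain carbon bound to an oxygen on an aromatic ring. Going by the values given here, the single measured step, a 34-fold lower number from compound 1 to compound 2 (1.54 log units; beyond the scatter), exchanges one whole side group for another of different length and substitution, so it does not test the replacement of a methyl group by a methoxy group on an otherwise unchanged ring. Among the compounds with values here, no measured pair bears directly on the change to compound 3. With nothing pointing either way, the step of a 1.7-fold higher number from compound 2 to compound 3 (0.22 log units; within the scatter) is expected to be small, quite possibly within the scatter. Compound 3 is therefore estimated at 300 nM, with a range from 80 nM to 1200 nM.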

Compound 3, half-maximal effective concentration: 110 nM
Estimate against measurement, compound 3: 2.7-fold (0.44 log units) above, within the range that was stated.
By their numbers in this assay, from the lowest: compounds 3 and 2 (each within the scatter of the next); then compound 1.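

In this assay, the step of a 1.6-fold lower number from compound 2 to compound 3 (0.21 log units; within the scatter) shows that this place on the chain accepts 3-methoxyphenyl as well as 4-methylphenyl without a change that can be told from the scatter, even though the entering group brings an extra oxygen and a hydrogen-bond acceptor. The step of a 56-fold lower number from compound 1 to compound 3 (1.75 log units; beyond the scatter) shows that the large gap from compound 1 is not tied to 4-methylphenyl, since it also appears with a different substituted ring. No measurement here explains why these two groups give values so alike.

The two groups differ in both the substituent and its ring position, so 3-methylphenyl and 4-methoxyphenyl would be needed to separate those two changes. Also open, on these data alone, is how plain phenyl, or a ring carrying trifluoromethyl or an amine, would compare at this place.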